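The compounds below may be only part of what the source reports. "The series", "measured", "known", "first", "only" and "open" are said of these compounds alone.

Measured compounds:
- compound 1 `COc1cc2c(Oc3ccc(NC(=O)c4cc(-c5ccc(C(F)(F)F)cc5)ccn4)cc3F)ccnc2cc1OCCCN1CCCCC1` — in a functional assay on MKN-45 cells (Homo sapiens) for cytotoxicity, read by MTT assay, with a stated time of 72 h (a lower number here means a stronger inhibitor, a higher number a weaker inhibitor), compound 1 gives 870 nM
- compound 2 `COc1ccc(-c2ccnc(C(=O)Nc3ccc(Oc4ccnc5cc(OCCCN6CCCCC6)c(OC)cc45)c(F)c3)c2)cc1` — in this assay compound 2 gives 570 nM
- compound 3 `COc1cc2c(Oc3ccc(NC(=O)c4cc(-c5ccccc5C)ccn4)cc3F)ccnc2cc1OCCCN1CCN(C)CC1` — in this assay compound 3 gives 240 nM

Compound 3 stands at the lowest number of the three, and its gaps to compound 2 and to compound 1 are both beyond the scatter, so it is the strongest inhibitor measured so far in this set.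

Compound 4 `COc1cc2c(Oc3ccc(NC(=O)c4cc(-c5ccccc5F)ccn4)cc3F)ccnc2cc1OCCCN1CCN(C)CC1` differs from compound 3 in one place: fluoro in place of methyl on an aromatic carbon. Going by the values given here, the only single-point step measured so far is a 1.5-fold lower number from compound 1 to compound 2 (0.18 log units; within the scatter), an exchange of one group for another on an aromatic carbon that stayed within the scatter. It involves neither methyl nor fluoro, so it bears on the present change only loosely, as a sign that a small swap on that aromatic carbon need not move the number much. Among the compounds with values here, no measured pair shows methyl against fluoro directly.

In this assay the step from compound 3 to compound 4 is therefore expected to be small, a 1.3-fold higher number from compound 3 to compound 4 (0.12 log units; within the scatter), with no clear direction beyond the scatter. Compound 4 is estimated at 320 nM, with a range from 130 nM to 800 nM.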

Compound 4, half-maximal inhibitory concentration: 150 nM
Compound 4: middle estimate off by 2.1-fold (0.33 log units), on the high side; low and high end bracket the measured number.
By their numbers in this assay, from the lowest: compounds 4 and 3 (each within the scatter of the next); then compounds 2 and 1 (each within the scatter of the next).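

In this assay, going by these compounds alone, fluoro in place of methyl on this aromatic carbon, ortho to a large group, gives a 1.6-fold lower number from compound 3 to compound 4 (0.20 log units; within the scatter), the first direct reading of these two groups against each other. At this position, the 2-methylphenyl and 2-fluorophenyl forms therefore cannot be told apart in this assay, and neither group can be ranked above the other. No measurement bearing on the properties of these groups accompanies the result.

On these data alone, it remains open whether an amine, a carboxylic acid or a longer chain on this aromatic carbon would move the number beyond the scatter. Also open, as far as these compounds go, is whether the same exchange gives a similar step on the different side chain carried by compound 1 and compound 2.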